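Pyridin-2-yl for Phenyl in a Cytotoxicity Comparison

The compounds below may be only part of what the source reports. "The series", "measured", "known", "first", "only" and "open" are said of these compounds alone.

In a functional assay on T47D cells (Homo sapiens) for cytotoxicity, read by colorimetric assay and MTT assay (a higher number here means a weaker inhibitor, a lower number a stronger inhibitor), compound 1 `Oc1ccc(-c2cc3c(O)cc(O)cc3nc2O)cc1` gives 10000 nM. Compound 2 `COc1ccc(-c2cc3c(OC)cc(OC)cc3n(C)/c2=N\Nc2ccccc2)cc1`, which carries a phenyl on an amine nitrogen, gives 10000 nM in this assay. That places it level with compound 1, so neither of the two stands out as the stronger inhibitor. Compound 3 `COc1ccc(-c2cc3c(OC)cc(OC)cc3n(C)/c2=N\Nc2ccccn2)cc1` keeps the rest of compound 2 and has pyridin-2-yl in place of phenyl on that amine nitrogen: pyridin-2-yl in place of phenyl on an amine nitrogen. Going by the values given here, no measured pair shows what this exchange does, so the only guide is compound 2 at 10000 nM. The estimated step of a 1.3-fold lower number from compound 2 to compound 3 (0.10 log units; within the scatter) is small, leaning slightly towards a stronger inhibitor, and is not expected to go beyond the scatter. Compound 3 is expected at 8000 nM, with an estimated range from 2000 nM to 15000 nM.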

Compound 3, half-maximal inhibitory concentration: 10000 nM
Compound 3: middle estimate off by 1.3-fold (0.10 log units), on the low side; the measured number falls inside the stated range.
By their numbers in this assay, from the lowest: compounds 1, 2 and 3 (each within the scatter of the next).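

In this assay, going by these compounds alone, pyridin-2-yl in place of phenyl on an amine nitrogen gives no change at the digits printed from compound 2 to compound 3 (within the scatter), which is the first measured step at this position. On this single pair, the exchange of a carbon-only ring for one with a hetero atom, which adds a hydrogen-bond acceptor, leaves the number unchanged at the digits printed. Nothing measured here gives a reason for this outcome.

Going by these compounds, compounds 2 and 3 carry only these two aromatic rings at this place, so it remains open whether a non-aromatic group such as piperidin-1-yl or acetyl on that amine nitrogen would shift the number. On these data alone, it also remains open whether the same exchange would read alike with another group, such as an amine, elsewhere on the shared core.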